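Aryl variation next to the ring sulfur: compound 3 to compound 4

This account rests on a few compounds, and the source may have more. Where it says the series, first, only, none or still open, it means among the compounds named here.

The series shares one core and differs only in the aryl group on the aromatic carbon next to the ring sulfur. In an assay on CHO cells for displacement of a labelled ligand from adenosine receptor A3 (Homo sapiens), read by scintillation counting, tested at 10 uM (a lower number here means less inhibition, a higher number more inhibition at the concentration tested (going by the name of the read-out)), compound 1 `CC(C)(C)Cc1c(-c2ccncc2)sc(N)c1C(=O)c1ccc(Cl)cc1` gives 6%, compound 2 `CC(C)(C)Cc1c(-c2cccnc2)sc(N)c1C(=O)c1ccc(Cl)cc1` gives 1%, and compound 3 `CC(C)(C)Cc1c(-c2c(F)cccc2F)sc(N)c1C(=O)c1ccc(Cl)cc1` gives 1%. The three steps between them are all small: a number 5 percentage points lower from compound 1 to compound 2 (within the scatter), a number 5 percentage points lower from compound 1 to compound 3 (within the scatter) and no change at the digits printed from compound 2 to compound 3 (within the scatter). On these numbers compound 3 stands level with compound 2 at the digits shown, the two together the lowest of the three values, with compound 1 the furthest away, and every gap lies within the scatter.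

Compound 4 `COc1cccc(-c2sc(N)c(C(=O)c3ccc(Cl)cc3)c2CC(C)(C)C)c1` continues the same exchange: 3-methoxyphenyl in place of 2,6-difluorophenyl on an aromatic carbon. The three measured steps all bear on it, since each swapped the aryl group at this same place, and none of them moved this assay beyond the scatter. The expectation for compound 4 is therefore no step beyond the scatter, a number 2 percentage points higher from compound 3 to compound 4 (within the scatter). In this assay compound 4 is estimated at 3%, with a range from -7% to 13%.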

Compound 4, a percentage reported as inhibition, at one concentration (the size of the read-out at that concentration, not a potency): 1%
For compound 4 the middle estimate is 2 percentage points above the measured one; the measured number falls inside the stated range.
By their numbers in this assay, from the lowest: compounds 2, 3, 4 and 1 (each within the scatter of the next).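

In this assay, 3-methoxyphenyl brings a hydrogen-bond acceptor to the aromatic carbon next to the ring sulfur, where 2,6-difluorophenyl has none, yet the read-out shows no change at the digits printed from compound 3 to compound 4 (within the scatter). The comparisons with the two pyridine-bearing compounds give the same picture, with no change at the digits printed from compound 2 to compound 4 (within the scatter) and a number 5 percentage points lower from compound 1 to compound 4 (within the scatter), so a methoxy-substituted phenyl now joins the pyridin-4-yl, pyridin-3-yl and 2,6-difluorophenyl groups, and all four compounds lie within the scatter of one another at this position. No data in hand explain why this exchange leaves the read-out flat.

The compounds shown leave open whether an aryl group carrying an aminomethyl or carboxylic acid substituent would move the read-out beyond the scatter at this position. They also leave open whether replacing the neopentyl group or the (4-chlorophenyl)carbonyl group with a different group, such as a longer alkyl chain or an unsubstituted benzoyl group, would make this aryl position matter.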